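The compounds below may be only part of what the source reports. "The series", "measured", "known", "first", "only" and "open" are said of these compounds alone.

In a functional assay on HL-60 cells (Homo sapiens) for inhibition, read by CCK-8 assay, with a stated time of 48 h, tested at 20 uM (a higher number here means more inhibition of growth at the concentration tested, a lower number less inhibition of growth), compound 1 `COc1ccc(S(=O)(=O)Oc2ccccc2/C=C(\C#N)C(=O)Nc2nnc(Cc3cccc4ccccc34)s2)cc1` gives 98% in these working notes on the series. Compound 2 `Cc1ccc(S(=O)(=O)Oc2ccccc2/C=C(\C#N)C(=O)Nc2nnc(Cc3ccc(F)cc3)s2)cc1` is reported as "not active" (no number reported) and has no number, so its standing is only a qualitative one at the low end of the two results. Going by the values given here, no measured step links compound 1 and compound 2, and the gap between their results cannot be assigned to any one place. Compound 3 `COc1ccc(S(=O)(=O)Oc2ccccc2/C=C(\C#N)C(=O)Nc2nnc(Cc3ccc(F)cc3)s2)cc1` follows from compound 2 by one change, (methoxy in place of methyl on an aromatic carbon), with methoxy in place of methyl on an aromatic carbon, para to a large group. Among the compounds with values here, with no measured step to go on, a modest rise in this assay is expected, and no change beyond the scatter remains quite possible. For compound 3 the estimated value is 25%, with an expected range from 5% to 65% as the likely span.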

Compound 3, percent growth inhibition at one concentration: 100%
Beside the measured number, compound 3's estimate is 75 percentage points below it; the measured number lies above the stated range.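

In this assay compound 2 is reported as "not active" (no number reported) and compound 3 gives 100%, so the whole gap between these two results sits on methoxy in place of methyl on an aromatic carbon, para to a large group. With the 4-methoxyphenyl group held, the other place shows a number 2 percentage points higher from compound 1 to compound 3 (within the scatter), so naphthalen-1-yl and 4-fluorophenyl are not told apart in this read-out. Compound 3 thus links the two earlier compounds, and the gap that could not be placed before now appears at the methyl-to-methoxy change.

As far as these compounds go, whether methyl also gives no activity with naphthalen-1-yl at the other place stays open. So does the outcome for an ethoxy, a hydroxyl or a dimethylamino group at this aromatic carbon. No measurement at hand speaks to what lies behind the difference.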